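Fluoro for methoxy on the fused ring of compound 3

A few compounds are considered here, and "the series" means these few. Any claim that something is new, unique, unknown or untested is made for them only; others in the source may bear on it.

In an assay on HEK293 cells for displacement of a labelled ligand from transient receptor potential cation channel subfamily V member 1 (Homo sapiens) (on this read-out higher numbers stand for weaker inhibition and lower numbers for stronger inhibition), compound 3 `COc1ccc2c(c1)CCC(NC(=O)Nc1cccc3cnccc13)C2Cc1ccc(C(F)(F)F)cc1` gives 2 nM, the second highest of the three numbers. Compound 1 `O=C(Nc1cccc2cnccc12)NC1CCc2cc(F)ccc2C1Cc1ccccc1` gives 4 nM, a value within the scatter of that of compound 3. Among the measured compounds shown here, compound 2 `O=C(Nc1cccc2cnccc12)NC1CCc2cc(F)ccc2C1CC1CC1` gives 0.8 nM, and its step to compound 3 lies beyond the scatter; the one measured step, a 5.0-fold lower number from compound 1 to compound 2 (0.70 log units; beyond the scatter), concerns the cyclopropyl in place of phenyl and not the change at hand.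

Compound 4 `O=C(Nc1cccc2cnccc12)NC1CCc2cc(F)ccc2C1Cc1ccc(C(F)(F)F)cc1` differs from compound 3 by fluoro in place of methoxy on an aromatic carbon. For the measured compounds named here, no measured step bears directly on this exchange. Going by the values given here, compound 1 also carries fluoro on the fused ring where compound 3 carries methoxy, yet the two also differ in the trifluoromethyl, so their values show only that the two numbers sit within the scatter of each other.

On that basis the step from compound 3 to compound 4 is expected to be none beyond the scatter, no change at the digits printed from compound 3 to compound 4 (within the scatter). Compound 4 is therefore estimated at 2 nM in this assay, with a range from 0.7 nM to 6 nM.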

Compound 4, inhibition constant: 1 nM
The estimate for compound 4 lay 2.0-fold (0.30 log units) above the measured number, within the range that was stated.
By their numbers in this assay, from the lowest: compounds 2, 4, 3 and 1 (each within the scatter of the next, the first and the last beyond it).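

In this assay the exchange at this aromatic carbon, meta to a fused ring and para to a fused ring, is a small one: a 2.0-fold lower number from compound 3 to compound 4 (0.30 log units; within the scatter) shows that, with 4-(trifluoromethyl)phenyl on the chain, fluoro and methoxy cannot be told apart here. With fluoro held in place, the trifluoromethyl does register, as a 4.0-fold lower number from compound 1 to compound 4 (0.60 log units; beyond the scatter) is a step beyond the scatter, whereas a 1.3-fold higher number from compound 2 to compound 4 (0.10 log units; within the scatter) leaves 4-(trifluoromethyl)phenyl and cyclopropyl on the saturated chain carbon within the scatter of each other. Nothing measured alongside these numbers accounts for them.

The compounds shown leave open whether an amine or a carboxylic acid on that aromatic carbon would hold the number in the same place. They also leave open whether methoxy and fluoro would stay as close with cyclopropyl on the chain.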